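Trifluoroethyl for ethyl at the carbonyl-bound oxygen of compound 1

A few compounds are considered here, and "the series" means these few. Any claim that something is new, unique, unknown or untested is made for them only; others in the source may bear on it.

Measured so far:
compound 1, `CCOC(=O)c1cccc(-c2ccc(OCC)cc2)c1`, 87%
compound 2, `CCOC(=O)c1cccc(-c2ccc(C(C)=O)cc2)c1`, 36%

In an assay on COS-7 cells for inhibition of patatin-like phospholipase domain-containing protein 2 (Mus musculus), tested at 200 uM (a lower number here means less inhibition, a higher number more inhibition at the concentration tested (going by the name of the read-out)), compound 1 gives 87%, the highest of the two numbers. Among the compounds with values here, its only neighbour, compound 2, gives 36%, and the single measured step, a number 51 percentage points lower from compound 1 to compound 2 (beyond the scatter), is large. Compound 3, `CCOc1ccc(-c2cccc(C(=O)OCC(F)(F)F)c2)cc1`, is not yet measured. It differs from compound 1 by trifluoromethyl in place of methyl on a saturated chain carbon bound to an oxygen next to a carbonyl group. Within the data shown here, the one measured step concerns a change on an aromatic carbon and does not touch the part of the structure altered here, so no measured step bears directly on the move from compound 1 to compound 3. With no comparable change in hand, the expectation for compound 3 is a step of a number 7 percentage points lower from compound 1 to compound 3 (within the scatter), not clearly beyond the scatter in either direction. Compound 3 is therefore estimated at 80%, with a range from 55% to 95%.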

Compound 3, a percentage reported as inhibition, at one concentration (the size of the read-out at that concentration, not a potency): 71%
The estimate for compound 3 lay 9 percentage points above the measured number; measured number inside the range.
By their numbers in this assay, from the lowest: compound 2; then compound 3; then compound 1.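

In this assay, within the data shown here, the change gives a number 16 percentage points lower from compound 1 to compound 3 (beyond the scatter), the first reading at this position: trifluoromethyl in place of methyl on a saturated chain carbon bound to an oxygen next to a carbonyl group is not neutral here, yet compound 3 still gives 71%. The step is modest, whereas the change on the aromatic carbon gave a number 51 percentage points lower from compound 1 to compound 2 (beyond the scatter), so of the two changes seen from compound 1, acetyl in place of ethoxy has the larger effect. No measurement at hand speaks to why the number falls at this position.

The compounds shown leave open how this position responds to other groups, such as a propyl chain, an amide or a free carboxylic acid. They also leave open whether 2,2,2-trifluoroethyl gives a similar step on the core of compound 2.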